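This account rests on a few compounds, and the source may have more. Where it says the series, first, only, none or still open, it means among the compounds named here.

Three compounds have values in a functional assay on A549 cells (Homo sapiens) for inhibition, read by MTT assay, with a stated time of 72 h; on this read-out higher numbers stand for weaker inhibition and lower numbers for stronger inhibition

Compound 1 (`COc1ccc(-c2nnc(SCCCN3CCN(c4nc5ccccc5o4)CC3)o2)cc1`) gives 93500 nM
Compound 2 (`O=[N+]([O-])c1ccc(-c2nnc(SCCCN3CCN(c4nc5ccccc5o4)CC3)o2)cc1`) gives 90800 nM
Compound 3 (`Clc1ccc(-c2nnc(SCCCN3CCN(c4nc5ccccc5o4)CC3)o2)cc1`) gives 127000 nM

These three numbers cannot be put in a firm order, and compound 1 stands level with the other two. Measured against it, the results are a 1.0-fold lower number from compound 1 to compound 2 (0.01 log units; within the scatter) and a 1.4-fold higher number from compound 1 to compound 3 (0.13 log units; within the scatter). The remaining pair shows the same picture, with a 1.4-fold higher number from compound 2 to compound 3 (0.15 log units; within the scatter).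

The next compound is compound 4 (`Fc1ccc(-c2nnc(SCCCN3CCN(c4nc5ccccc5o4)CC3)o2)cc1`), which has not yet been measured. It keeps the rest of compound 1 and carries fluoro in place of methoxy on an aromatic carbon, para to a large group, so that 4-methoxyphenyl becomes 4-fluorophenyl. The counted difference is fluoro in place of methoxy on an aromatic carbon.

Fluoro itself has not been tested here, so the evidence is indirect. Two other replacements of the methoxy group give the nearest guide. Chloro in compound 3 produced a 1.4-fold higher number from compound 1 to compound 3 (0.13 log units; within the scatter), and nitro in compound 2 produced a 1.0-fold lower number from compound 1 to compound 2 (0.01 log units; within the scatter). Neither replacement moved the number measurably, so no step beyond the scatter is expected in this assay, in either direction. The expected result is a 1.1-fold higher number from compound 1 to compound 4 (0.03 log units; within the scatter). For compound 4 the estimated value is 100000 nM, with an expected range from 55000 nM to 180000 nM.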

Compound 4, half-maximal inhibitory concentration: 75700 nM
Compound 4: the middle estimate sits 1.3-fold (0.12 log units) above what was measured, and the stated range covers the measured number.
By their numbers in this assay, from the lowest: compounds 4, 2, 1 and 3 (each within the scatter of the next).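

In this assay, fluoro on this aromatic carbon, para to a large group, gives a 1.2-fold lower number from compound 1 to compound 4 (0.09 log units; within the scatter). Set against the other two groups, it gives a 1.7-fold lower number from compound 3 to compound 4 (0.22 log units; within the scatter) and a 1.2-fold lower number from compound 2 to compound 4 (0.08 log units; within the scatter). Methoxy, nitro, chloro and fluoro therefore all read alike at this position, and the swap from methoxy to fluoro, which takes two heavy atoms down to one, adds a fourth group without producing a step beyond the scatter, so this position has not yet shown a measurable response to the group it carries. No supporting measurement is available to say why these four groups read alike.

On these data alone, it remains open whether a group of a different kind at this position, such as an amine, a carboxylic acid or a longer chain, would read differently. As far as these compounds go, the four compounds differ only at this one position, so whether a change elsewhere in the shared core would move the number also stays open.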